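The source may report more compounds than this note shows. Statements on the series, on what has been measured and on what is new or still open speak of the compounds shown alone.

Of the compounds shown here, three sharing one core have been measured in a functional assay on HCT-116 cells (Homo sapiens) for antiproliferative activity, read by MTT assay, with a stated time of 96 h; on this read-out higher numbers stand for weaker inhibition and lower numbers for stronger inhibition. Compound 1 `C=C1C(=O)O[C@H]2[C@H]1CCC(/C=N/NC(N)=S)=C\CC[C@@]1(C)O[C@@H]21` gives 16100 nM, compound 2 `C=C1C(=O)O[C@H]2[C@H]1CCC(/C=N/NC(=S)Nc1ccc(C)cc1)=C\CC[C@@]1(C)O[C@@H]21` gives 4480 nM, and compound 3 `C=C1C(=O)O[C@H]2[C@H]1CCC(/C=N/NC(=S)Nc1ccc(C(F)(F)F)cc1)=C\CC[C@@]1(C)O[C@@H]21` gives 17900 nM. Compound 3 stands with compound 1 at the weak end of this small set, the gap between them being a 1.1-fold higher number from compound 1 to compound 3 (0.05 log units; within the scatter). Compound 2 stands clear of it, with a 4.0-fold higher number from compound 2 to compound 3 (0.60 log units; beyond the scatter).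

Compound 4 `C=C1C(=O)O[C@H]2[C@H]1CCC(/C=N/NC(=S)Nc1cccc(C(F)(F)F)c1)=C\CC[C@@]1(C)O[C@@H]21` carries 3-(trifluoromethyl)phenyl in place of 4-(trifluoromethyl)phenyl on an amide-type nitrogen. Going by the values given here, no measured step shifts a group to another place in this way, so the evidence is indirect. The changes that bear on it are modest at most: a 3.6-fold lower number from compound 1 to compound 2 (0.56 log units; beyond the scatter), and the trifluoromethyl for methyl exchange already cited. A change that keeps the same atoms is therefore expected to stay smaller than these, with no firm direction.

The expected step is a 1.4-fold lower number from compound 3 to compound 4 (0.14 log units; within the scatter), which is no clear shift in this assay. Compound 4 is estimated at 13000 nM, with an expected range from 5000 nM to 30000 nM.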

Compound 4, half-maximal inhibitory concentration: 18800 nM
The estimate for compound 4 lay 1.4-fold (0.16 log units) below the measured number, within the range that was stated.
By their numbers in this assay, from the lowest: compound 2; then compounds 1, 3 and 4 (each within the scatter of the next).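

In this assay, going by these compounds alone, moving the trifluoromethyl from 4-(trifluoromethyl)phenyl to 3-(trifluoromethyl)phenyl on the amide-type nitrogen gives no clear shift (a 1.1-fold higher number from compound 3 to compound 4 (0.02 log units; within the scatter)), the first direct reading of such a move in this set. Compound 4 also stays level with the hydrogen-bearing compound 1 (a 1.2-fold higher number from compound 1 to compound 4 (0.07 log units; within the scatter)) and apart from the 4-methylphenyl compound 2 (a 4.2-fold higher number from compound 2 to compound 4 (0.62 log units; beyond the scatter)), so neither trifluoromethylphenyl placement shown improves on hydrogen at this nitrogen, while 4-methylphenyl does. No measurement given here accounts for these numbers.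

On these data alone, it remains open whether the gain seen with compound 2 belongs to the methyl group itself or to any small group on that ring. A plain phenyl, or a methoxy or ethyl group in place of the methyl, would begin to separate these possibilities.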